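This account rests on a few compounds, and the source may have more. Where it says the series, first, only, none or still open, it means among the compounds named here.

Measured so far in a functional assay on ZR-75-1 cells (Homo sapiens) for cytotoxicity, read by MTT assay, with a stated time of 72 h (a lower number here means that less compound is needed, a higher number that more compound is needed for the effect), are three compounds
Compound 1 `CCOc1c(-c2occ(C)c2C(=O)O)ccc2c(CC)cccc12` gives > 10 ug/mL (a limit, not a number)
Compound 2 `CCc1cccc2c(OC)c(-c3occ(C)c3C(=S)OC)ccc12` gives 5.8 ug/mL
Compound 3 `CCc1cccc2c(OC)c(-c3occ(C)c3C(=O)On3nnc4ccccc43)ccc12` gives > 10 ug/mL (a limit, not a number)

Within the data shown here, compound 2, at 5.8 ug/mL as the only true number in the set, is the natural starting point. The other two results give no exact figure, and the evidence on them is simply the limit of > 10 ug/mL in this assay, at which 2 of the 3 values shown sit, and nothing finer.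

Compound 4 `CCc1cccc2c(OC)c(-c3occ(C)c3CBr)ccc12` keeps the core of compound 2 and changes one group (a group of 2 heavy atoms (1 carbon, 1 bromine; no ring) in place of a group of 4 heavy atoms (2 carbon, 1 oxygen, 1 sulfur; no ring), on an aromatic carbon). Bromomethyl enters on an aromatic carbon of a five-membered aromatic ring with 1 oxygen, in place of a group without a ring.

Among the measured compounds shown here, no measured pair in this set shows what a change at this place does. The expected step of a 1.2-fold lower number from compound 2 to compound 4 (0.06 log units; within the scatter) in this assay is therefore none beyond the usual scatter, in either direction. A result that returns only a limit also remains possible for compound 4. For compound 4 the estimated value is 5 ug/mL with an expected range from 1.5 ug/mL to 15 ug/mL in this measurement.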

Compound 4, concentration for half-maximal effect: 4.6 ug/mL
Beside the measured number, compound 4's estimate is 1.1-fold (0.04 log units) above it, and the stated range covers the measured number.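

In this assay, this place on the five-membered aromatic ring with 1 oxygen accepts a very different group: putting bromomethyl in place of the sulfur-bearing group gives a 1.3-fold lower number from compound 2 to compound 4 (0.10 log units; within the scatter) and so no change that can be told from scatter. Among these compounds, this is the first measured pair at this place, and it shows that the number holds even though the entering group has fewer heavy atoms, no double bond outside aromatic rings and no hydrogen-bond acceptors. Nothing measured here explains why the two compounds read alike.

On these data alone, whether an amine, a hydroxymethyl or a longer chain at this place would also keep the number in this range stays open. One pair also cannot tell whether the same exchange would behave alike on a different core.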